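An Iodo Analogue Tested Against the Bromo Precedent

The source may hold more compounds than are shown below. What is called first, only, known or untested is meant among the compounds shown, and "the series" means these compounds.

The measured compounds, with their numbers in an assay on HEK293 cells for displacement of a labelled ligand from Neuronal acetylcholine receptor; alpha3/beta4 (Homo sapiens), read by radioligand binding, with a stated time of 5 min (a higher number here means a weaker inhibitor, a lower number a stronger inhibitor), are these:
compound 1, `Oc1cccc(C2=NCCCC2)c1`, 680 nM
compound 2, `Brc1cccc(C2=NCCCC2)c1`, 29.8 nM
compound 3, `c1ccc(C2=NCCCC2)cc1`, 194 nM

All three share one core and differ only in a single group on an aromatic carbon. Compound 3 stands second highest of the three numbers. Its nearest neighbour is reached by a 3.5-fold lower number from compound 1 to compound 3 (0.54 log units; beyond the scatter), the furthest by a 6.5-fold higher number from compound 2 to compound 3 (0.81 log units; beyond the scatter); both steps lie beyond the scatter.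

Compound 4, `Ic1cccc(C2=NCCCC2)c1`, differs from compound 3 by iodo in place of hydrogen on an aromatic carbon.

Among the compounds with values here, two measured steps bear on this change. The direct precedent is the removal of bromo: a 6.5-fold higher number from compound 2 to compound 3 (0.81 log units; beyond the scatter), so reversing it, a halogen entering in place of hydrogen, would be a modest move to a lower number. The larger jump a 23-fold lower number from compound 1 to compound 2 (1.36 log units; beyond the scatter) shows that the bromo compound is the strongest binder among the three. An iodo group entering at the same aromatic carbon is expected to behave like bromo, giving a modest step to a lower number in this assay, beyond the scatter.

Compound 4 is therefore estimated at 25 nM, within the range 8 nM to 80 nM, which amounts to an expected 7.8-fold lower number from compound 3 to compound 4 (0.89 log units; beyond the scatter).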

Compound 4, inhibition constant: 4.7 nM
Beside the measured number, compound 4's estimate is 5.3-fold (0.73 log units) above it; measured number below the stated range.
By their numbers in this assay, from the lowest: compound 4; then compound 2; then compound 3; then compound 1.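

In this assay, within the data shown here, the earlier compounds showed only that bromo at this aromatic carbon gave a lower number than hydrogen or hydroxy, and compound 4 now separates one halogen from another, with a 6.3-fold lower number from compound 2 to compound 4 (0.80 log units; beyond the scatter) as a modest step, so that which halogen stands here matters and not merely that one is present. The entry of iodo in place of hydrogen gives a 41-fold lower number from compound 3 to compound 4 (1.62 log units; beyond the scatter) as a large step, where bromo at the same carbon had given only a modest one, and compound 4 is the strongest binder of the four. The span of the set widens as well, with a 140-fold lower number from compound 1 to compound 4 (2.16 log units; beyond the scatter) as the largest step among them, and the four groups at this carbon now run iodo, bromo, hydrogen, hydroxy from the lowest number to the highest.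

These four compounds leave open whether other groups at this carbon, such as methoxy, trifluoromethyl or an amine, would fall within this order, and whether iodo would give a step of like size on another carbon of the aromatic ring. Nothing measured here says why iodo and bromo part in this way.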